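Removing a chloro group on a low-potency amide series

The source may report more compounds than this note shows. Statements on the series, on what has been measured and on what is new or still open speak of the compounds shown alone.

Measured compounds:
- compound 1 `O=C1COc2ccc(-c3cccc(NS(=O)(=O)c4ccc(F)cc4)c3)cc2N1c1ccc(Cl)cc1`, 35000 nM
- compound 2 `O=C1COc2ccc(-c3cccc(NS(=O)(=O)c4ccc(F)cc4)c3)cc2N1c1ccccc1`, 17700 nM
- compound 3 `O=C1COc2ccc(-c3cnc4ccccc4c3)cc2N1c1ccc(Cl)cc1`, a limit of > 40000 nM

In a functional assay on HeLa cells (Homo sapiens) for antiproliferative activity, read by MTT assay, with a stated time of 72 h (a lower number here means a stronger inhibitor, a higher number a weaker inhibitor), compound 1 gives 35000 nM. Compound 2 carries the change hydrogen in place of chloro on an aromatic carbon and gives 17700 nM. The resulting step, a 2.0-fold lower number from compound 1 to compound 2 (0.30 log units; within the scatter), lies within the usual scatter, so the two values cannot be told apart with confidence.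

Compound 3 shares the amide core but carries a different aromatic group on it; the difference between the two cores is not broken down here. In this assay compound 3 reaches only a limit, > 40000 nM, which is a boundary of the measurement rather than a number, as noted in the limit of > 40000 nM in this assay, at which 1 of the 3 values shown sits.

Compound 4 `O=C1COc2ccc(-c3cnc4ccccc4c3)cc2N1c1ccccc1` is not yet measured. It differs from compound 3 by hydrogen in place of chloro on an aromatic carbon, the same change as between compound 1 and compound 2, at the same kind of place. Because a 2.0-fold lower number from compound 1 to compound 2 (0.30 log units; within the scatter) was within the scatter, the expected step is small: a number no higher from compound 3 to compound 4 (the limit leaves the size open). Compound 4 is therefore estimated at 40000 nM, in the range 15000 nM to 90000 nM, with a real chance that this assay again reports only a limit.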

Compound 4, half-maximal inhibitory concentration: > 40000 nM
Compound 4 was reported as a limit; the forecaster's own chance of this, stated with the estimate: 60%; the middle value lies on the limit itself.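

In this assay compound 3 and compound 4 both end at a limit of the assay rather than a number, so the step between them cannot be read: the limit of > 40000 nM in this assay, at which 2 of the 4 values shown sit.

The compounds shown leave open whether the change from 4-chlorophenyl to phenyl alters activity at all when the core carries the aromatic group of compound 3 and compound 4.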